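From Methyl to Phenyl: Estimating a Yet Unmeasured Compound

The source may hold more compounds than are shown below. What is called first, only, known or untested is meant among the compounds shown, and "the series" means these compounds.

In a functional assay on PBMC cells (Homo sapiens) for inhibition, read by HTRF, with stated times of 15 min and 24 h (a higher number here means a weaker inhibitor, a lower number a stronger inhibitor), three compounds have been measured so far. Compound 1 `O=C(Nc1ccc2c(c1)B(O)OC2)c1ccccc1C(F)(F)F`, which carries a trifluoromethyl group, gives 2100 nM in this assay. Compound 2 `O=C(Nc1ccc2c(c1)B(O)OC2)c1ccccc1` reaches only the limit of the assay, > 100000 nM. Compound 3 `Cc1ccccc1C(=O)Nc1ccc2c(c1)B(O)OC2` likewise reaches only the limit, > 100000 nM. The step of an at least 47-fold higher number from compound 1 to compound 2 (1.67 log units; beyond the scatter) and the step of an at least 47-fold higher number from compound 1 to compound 3 (1.67 log units; beyond the scatter) are both large, while the step that the two limits leave unreadable from compound 2 to compound 3 cannot be read, since both values sit at the limit of > 100000 nM in this assay, at which 2 of the 3 values shown sit. Compound 3 thus stands at the assay limit, with no number measured.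

Compound 4 `O=C(Nc1ccc2c(c1)B(O)OC2)c1ccccc1-c1ccccc1` differs from compound 3 by phenyl in place of methyl on an aromatic carbon. The two measured steps that bear on this spot show that trifluoromethyl gives a far lower number than methyl or hydrogen, but none shows what a larger group does here. Only a modest shift is expected: the step of an at least 2.0-fold lower number from compound 3 to compound 4 (0.30 log units; that floor lies within the scatter) is estimated from a starting point that is itself only a limit. Compound 4 is expected to give about 50000 nM, within a range from 5000 nM to 200000 nM, and may again report only a limit.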

Compound 4, half-maximal inhibitory concentration: > 100000 nM
Compound 4: no number, only a limit (the forecaster's own chance of this, stated with the estimate: 55%); middle value at least 2.0-fold (0.30 log units) away from the limit.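

In this assay, a much larger group at this place, ortho to a large group, does not give what trifluoromethyl gives: phenyl, with 6 heavy atoms against 1 for methyl, produces an at least 47-fold higher number from compound 1 to compound 4 (1.67 log units; beyond the scatter). So size alone, from methyl up to phenyl, gives no number here, and among the compounds shown only compound 1 gives a measured value. Hydrogen, methyl and phenyl cannot be ranked against one another, and the steps among compound 2, compound 3 and compound 4 cannot be read: the limit of > 100000 nM in this assay, at which 3 of the 4 values shown sit.

The compounds shown leave open whether the measured value of compound 1 is particular to trifluoromethyl or would also appear with another group at this place, such as chlorine, methoxy or a nitrile. They also leave open how far compound 2, compound 3 and compound 4 lie past that limit.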